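A few compounds are considered here, and "the series" means these few. Any claim that something is new, unique, unknown or untested is made for them only; others in the source may bear on it.

Compound 1 `CCOC(=O)C12C(=O)OCC=C1COC2c1ccc(C(C)(C)C)cc1` gives > 1000000 nM in a functional assay on QGY cells (Homo sapiens) for cytotoxicity, read by MTT assay (on this read-out lower numbers stand for stronger inhibition and higher numbers for weaker inhibition), which is a limit of the assay and not a number.
Compound 2 `CCOC(=O)C12C(=O)OCC=C1COC2c1ccc(OC)cc1` gives > 1000000 nM in this assay, which is again a limit of the assay.

Compound 2 therefore stands only at a limit on the numbers shown, and both values sit at the same limit (the limit of > 1000000 nM in this assay, at which 2 of the 2 values shown sit). Within the data shown here, the single measured step, from compound 1 to compound 2, is a step that the two limits leave unreadable from compound 1 to compound 2, so it cannot be read in size or direction.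

Compound 3 `CCOC(=O)C12C(=O)OCC=C1COC2c1ccc([N+](=O)[O-])cc1` differs from compound 2 by nitro in place of methoxy on an aromatic carbon. Among the measured compounds shown here, no measured step gives readable information about this change, since the only step available is unreadable. In this assay the step from compound 2 to compound 3 is expected to be a number no higher from compound 2 to compound 3 (the limit leaves the size open), meaning no change beyond the scatter is expected. Compound 3 is therefore estimated at 1000000 nM, with a range from 100000 nM to 3000000 nM, most likely reported again only as a limit.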

Compound 3, half-maximal inhibitory concentration: > 1000000 nM
Compound 3: a limit, no number (the forecaster's own chance of this, stated with the estimate: 75%); the middle value lies on the limit itself.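

Compound 3 gives > 1000000 nM in this assay, again a limit of the assay and not a number, so its steps from compound 1 and compound 2 cannot be read. The compounds shown leave open whether tert-butyl, methoxy and nitro differ at all in this assay.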